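The compounds below may be only part of what the source reports. "The series", "measured", "known", "first", "only" and "open" are said of these compounds alone.

Measured compounds:
- compound 1, `O=C(NC(=S)NCc1ccc(C(F)(F)F)cc1)c1ccccc1`: "not active" (no number reported)
- compound 2, `COc1cc(NC(=S)NC(=O)c2ccccc2)cc(OC)c1`: 10%
- compound 3, `O=C(NC(=S)Nc1ccccc1)c1ccccc1`: 14%

All three were tested in an assay on isolated protein for inhibition of histone deacetylase 11 (Homo sapiens), read by fluorescence, tested at 100 uM; on this read-out lower numbers stand for less inhibition and higher numbers for more inhibition at the one concentration tested (going by the name of the read-out). Compound 1 comes back with no number at all; the outcome for compound 1 is simply "not active" (no number reported), so there is no value to place it on a scale against the others. Compound 2 gives 10% and compound 3 gives 14%, both small readings, and the gap between them lies within the usual scatter of this kind of measurement, so neither can be called stronger or weaker than the other.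

The unmeasured compound is compound 4, `O=C(NC(=S)NCc1ccccc1)c1ccccc1`. It is made from compound 1 by a single change, (hydrogen in place of trifluoromethyl on an aromatic carbon). Everything else in the shared core of compound 1 stays as it is.

Among the measured compounds shown here, no step between two measured compounds is available to show what this change does. With compound 1 giving no number and the two measured neighbours both low, the expectation for compound 4 is that its reading in this assay stays low, with a fair chance that it too is reported without a number. Compound 4 is estimated at 8%, within a range from 0% to 20%.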

Compound 4, a percentage reported as inhibition, at one concentration (the size of the read-out at that concentration, not a potency): "not active" (no number reported)
The entry for compound 4 holds no number; the estimate stays without a comparison.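

Among the compounds shown here, compound 1 and compound 4 are both reported without a number in this assay and no step between them can be read. The compounds shown leave open what replacing trifluoromethyl with hydrogen does to inhibition, and how either compound would compare with the others. Nothing available offers an explanation for this result.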